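Swapping Methoxyphenyl for Dichlorophenyl on an Anilino Linker

A few compounds are considered here, and "the series" means these few. Any claim that something is new, unique, unknown or untested is made for them only; others in the source may bear on it.

In an ADME assay on BJ cells (Homo sapiens) for cytotoxicity, with a stated time of 72 h (on this read-out higher numbers stand for an effect only at larger amounts of compound and lower numbers for an effect already at smaller amounts), compound 1 `C=C[C@@](C)(/C=C/c1ccc(OS(=O)(=O)c2ccc(C)cc2)cc1)CCC=C(C)C` reaches only the limit of the assay, > 36600 nM. Compound 2 `CCOc1ccc(/C=C/[C@@](C)(/C=C/c2ccc(O)cc2)CCC=C(C)C)cc1` likewise stops at the limit, giving > 36600 nM. Compound 3 `C=C[C@@](C)(/C=C/c1ccc(Nc2ccc(OC)cc2)cc1)CCC=C(C)C` gives > 36600 nM, again a limit rather than a measured number. Going by the values given here, every value shown therefore sits at the same boundary, as the limit of > 36600 nM in this assay, at which 3 of the 3 values shown sit, states, and no compound can be ranked against another; compound 3 simply stands where compounds 1 and 2 stand, at the edge of what the assay reports.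

Compound 4 `C=C[C@@](C)(/C=C/c1ccc(Nc2ccc(Cl)c(Cl)c2)cc1)CCC=C(C)C` differs from compound 3 in one place: 3,4-dichlorophenyl in place of 4-methoxyphenyl on a nitrogen on an aromatic ring. Among the compounds with values here, no pair of measured compounds differs by a single change, so no measured step can guide the size of this one. With all values resting at the limit, the plain expectation is that the new compound behaves like its neighbours. The step is expected to be none beyond the usual scatter, an at least 1.0-fold lower number from compound 3 to compound 4 (0.01 log units; that floor lies within the scatter). Compound 4 is estimated at 35000 nM in this assay, within a range from 9000 nM to 36600 nM, with a fair chance that the read-out once more comes back only as a limit.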

Compound 4, half-maximal effective concentration: > 36600 nM
Compound 4: only a limit was reported; the forecaster's own chance of this, stated with the estimate: 65%; at least 1.0-fold (0.01 log units) between middle value and limit.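

Going by these compounds alone, compound 4 comes back only as a limit, as compound 3 did, so no step between compound 3 and compound 4 can be read. All the values shown rest on one boundary: the limit of > 36600 nM in this assay, at which 4 of the 4 values shown sit.

As far as these compounds go, what stays open is how far apart these compounds really lie in this assay, and which change to the shared core, if any, would yield a measured number rather than a limit.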